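The source may hold more compounds than are shown below. What is called first, only, known or untested is meant among the compounds shown, and "the series" means these compounds.

Compound 1 `CNC(=O)CC1CCc2cc(OC)c(OC)cc21` has the lowest of the three numbers measured in a functional assay on the whole organism (strain Wistar) for inhibition, with Rattus norvegicus as the target, read by paw edema, with stated times of 60 min and 4 h, at a dose of 100 mg/kg by the oral route (on this read-out higher numbers stand for more inhibition at the one dose given (going by the name of the read-out) and lower numbers for less inhibition), giving 29.7%, though the gaps to the others lie within the usual scatter. Compound 2 `COc1cc2c(cc1OC)C(CC(=O)N(C)C)CC2` gives 35.9%, and compound 3 `COc1cc2c(cc1OC)C(CC(=O)NC(C)(C)C)CC2` gives 32.8%. The new compound 4 `COc1cc2c(cc1OC)C(CC(=O)N1CCCC1)CC2` differs from compound 1 by pyrrolidin-1-yl in place of methylamino on a carbonyl carbon. The two measured changes bearing on this place are a number 6.2 percentage points higher from compound 1 to compound 2 (within the scatter) and a number 3.1 percentage points higher from compound 1 to compound 3 (within the scatter), both within the scatter, so swapping groups on this nitrogen has so far hardly moved the read-out. The step of a number 3.3 percentage points higher from compound 1 to compound 4 (within the scatter) is therefore expected to be small, at most a slight rise. Compound 4 is estimated at 33%, with a likely range from 22% to 44%.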

Compound 4, a percentage reported as inhibition, in the whole organism at one dose (the size of the read-out at that dose, not a potency): 24.2%
Estimate against measurement, compound 4: 8.8 percentage points above; measured number inside the range.
By their numbers in this assay, from the lowest: compounds 4, 1, 3 and 2 (each within the scatter of the next, the first and the last beyond it).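

Among these compounds, only one step at this carbonyl carbon passes the usual scatter in this assay: a number 11.7 percentage points lower from compound 2 to compound 4 (beyond the scatter). The other two new steps stay inside it: a number 5.5 percentage points lower from compound 1 to compound 4 (within the scatter) and a number 8.6 percentage points lower from compound 3 to compound 4 (within the scatter). So pyrrolidin-1-yl separates from dimethylamino but not from methylamino or (tert-butyl)amino, and nothing measured here gives a reason for this.

Still open, on these data alone, is how a piperidine ring or a carboxylic acid at this carbonyl carbon would read in this assay. With a single dose, these numbers also cannot show how potency compares.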